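Replacing phenyl with tert-butoxycarbonyl on a ring nitrogen

The source may hold more compounds than are shown below. What is called first, only, known or untested is meant among the compounds shown, and "the series" means these compounds.

In a functional assay on MCF7 cells (Homo sapiens) for inhibition, read by MTT assay, with a stated time of 72 h (on this read-out lower numbers stand for stronger inhibition and higher numbers for weaker inhibition), compound 1 (`CN1CCN(c2cc(C(F)(F)F)nc(SCc3ccc(C(F)(F)F)cc3)n2)CC1`) gives 30200 nM as a measured number. Compound 2 (`FC(F)(F)c1ccc(CSc2nc(N3CCN(c4ccccc4)CC3)cc(C(F)(F)F)n2)cc1`) reads > 50000 nM in this assay and this is a limit of the assay, not a number.

Within the data shown here, the only measured step is an at least 1.6-fold higher number from compound 1 to compound 2 (0.21 log units; that floor lies within the scatter) when phenyl takes the place of methyl on an amine nitrogen in a ring. Compound 3 (`CC(C)(C)OC(=O)N1CCN(c2cc(C(F)(F)F)nc(SCc3ccc(C(F)(F)F)cc3)n2)CC1`) changes that same nitrogen again, with tert-butoxycarbonyl in place of phenyl (tert-butoxycarbonyl in place of phenyl on an amine nitrogen in a ring). No measured compound carries this group, so the step from compound 1 to compound 2 is a weak guide, and it gives no reason to expect a large move in either direction. Among the measured compounds shown here, the one firm number nearby is that of compound 1 at 30200 nM and the estimate leans on it.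

The expected step is an at least 1.4-fold lower number from compound 2 to compound 3 (0.15 log units; that floor lies within the scatter) and it is not expected to exceed the usual scatter. Compound 3 is estimated at 35000 nM in this assay with an expected range from 14000 nM to 80000 nM and a real chance of another limit.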

Compound 3, half-maximal inhibitory concentration: > 50000 nM
Compound 3: only a limit was reported; the forecaster's own chance of this, stated with the estimate: 45%; middle value at least 1.4-fold (0.15 log units) from the limit.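

In this assay, compound 3 reads > 50000 nM, which is a limit of the assay and not a number. Tert-butoxycarbonyl, which has no ring and carries two hydrogen-bond acceptors, therefore ends at the same limit as phenyl, so two very different groups on this ring nitrogen both fail to give a measured number; the step between those two limits cannot be read. Against methyl, the change gives an at least 1.6-fold higher number from compound 1 to compound 3 (0.21 log units; that floor lies within the scatter), so even this comparison does not establish a real loss, and the position can be described only coarsely for now: the limit of > 50000 nM in this assay, at which 2 of the 3 values shown sit.

Going by these compounds, how far compound 2 and compound 3 lie past the limit remains unknown, so these two compounds cannot be placed in any order. On these data alone, it also remains open whether a bare hydrogen, an ethyl group, a hydroxyethyl chain or a carboxylic acid on this ring nitrogen would give a number that could be compared directly with that of compound 1.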